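Swapping the Amide Aryl Group of Compound 1

The compounds below may be only part of what the source reports. "The series", "measured", "known", "first", "only" and "open" are said of these compounds alone.

Compound 1 `COc1ccc2c(=O)c(/C=C/C(=O)Nc3cc(C)ccc3C)coc2c1` was tested in a functional assay on A549 cells (Homo sapiens) for inhibition, read by MTT assay, with a stated time of 48 h (on this read-out lower numbers stand for stronger inhibition and higher numbers for weaker inhibition), where compound 1 gives 15500 nM. This is the highest of the two numbers seen, yet compound 2 `COc1ccc(NC(=O)/C=C/c2coc3cc(O)ccc3c2=O)cc1` gives 12800 nM in this assay, within the scatter of it. Compound 3 `Cc1ccccc1NC(=O)/C=C/c1coc2cc(O)ccc2c1=O` in this assay reached only the limit of > 100000 nM. Compound 4 `COc1ccc2c(=O)c(/C=C/C(=O)Nc3ccc(Cl)cc3)coc2c1` differs from compound 1 by 4-chlorophenyl in place of 2,5-dimethylphenyl on an amide-type nitrogen. Among the measured compounds shown here, the only measured step bearing on this change, an at least 7.8-fold higher number from compound 2 to compound 3 (0.89 log units; beyond the scatter), is bounded by the limit of > 100000 nM in this assay, at which 1 of the 3 values shown sits; it ran toward a 2-methylphenyl and the number rose, so compound 4, which drops a methyl-bearing ring for 4-chlorophenyl, is expected to move modestly the other way, a 1.9-fold lower number from compound 1 to compound 4 (0.29 log units; within the scatter). Compound 4 is therefore estimated at 8000 nM, between 3000 nM and 25000 nM.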

Compound 4, half-maximal inhibitory concentration: > 100000 nM
Compound 4 ended at the assay's limit (the forecaster's own chance of this, stated with the estimate: 5%); middle value at least 12-fold (1.09 log units) from the limit.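

In this assay, the change at this amide-type nitrogen gives an at least 6.4-fold higher number from compound 1 to compound 4 (0.80 log units; beyond the scatter). This is the first step shown on the core of compound 1 itself, and it shows that the aryl group at this position matters on that core too. The value of compound 4 is a limit and not a number: the limit of > 100000 nM in this assay, at which 2 of the 4 values shown sit.

The compounds shown do not separate the departure of the two methyl groups from the entry of chlorine. From the compounds shown here alone, whether a ring carrying an amine or a carboxylic acid would keep a measurable number on this core stays open.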